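Acid Ceramidase Inhibitors: Swapping an Ether Tail for Fluorophenylethyl

The compounds below may be only part of what the source reports. "The series", "measured", "known", "first", "only" and "open" are said of these compounds alone.

Compound 1 `CC(C)CNC(=O)n1c(=O)oc2cc(C3CCN(C)CC3)ccc21` and compound 2 `CN1CCC(c2ccc3c(c2)oc(=O)n3C(=O)NCCOCc2ccccc2)CC1` share a core and differ only in the chain on the amide-type nitrogen. In an assay on HEK293 cells for inhibition of acid ceramidase (Homo sapiens), read by fluorescence, with stated times of 10 min and 3 h (a higher number here means a weaker inhibitor, a lower number a stronger inhibitor), compound 1 gives 166 nM, and compound 2 gives 215 nM. The step of a 1.3-fold higher number from compound 1 to compound 2 (0.11 log units; within the scatter) shows that putting (benzyloxy)methyl in place of isopropyl left the result essentially unchanged. Among the two measured compounds, compound 2 carries the highest number, with compound 1 nearest to it. Compound 3 `CN1CCC(c2ccc3c(c2)oc(=O)n3C(=O)NCCCCc2ccc(F)cc2)CC1` has not yet been measured; it differs from compound 2 by 2-(4-fluorophenyl)ethyl in place of benzyloxy on a saturated chain carbon, two bonds along the chain from an amide-type nitrogen. Among the compounds with values here, the one measured step bears on this change only loosely, and it lay within the scatter, so the chain on this nitrogen has so far tolerated alteration without a shift in this assay. Sitting near compound 2, compound 3 is estimated at 200 nM, with a range of 80 nM to 550 nM. The expected step is a 1.1-fold lower number from compound 2 to compound 3 (0.03 log units; within the scatter).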

Compound 3, half-maximal inhibitory concentration in the acid ceramidase assay: 94 nM
Compound 3: the middle estimate sits 2.1-fold (0.33 log units) above what was measured; low and high end bracket the measured number.
By their numbers in the acid ceramidase assay, from the lowest: compounds 3, 1 and 2 (each within the scatter of the next, the first and the last beyond it).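

Within the data shown here, in the acid ceramidase assay, the swap of benzyloxy for 2-(4-fluorophenyl)ethyl gives the first step at this position that lies beyond the scatter, though a modest one: a 2.3-fold lower number from compound 2 to compound 3 (0.36 log units; beyond the scatter). The other new step, a 1.8-fold lower number from compound 1 to compound 3 (0.25 log units; within the scatter), stays within the scatter, so the gain holds against the ether tail only and not against the isobutyl chain. The same change also lowers solubility, for in a physicochemical assay for solubility, read by HPLC, in phosphate buffer, measured as kinetic solubility, with a stated time of 1 h, at pH 7.4, tested at 250 uM (a lower number here means a less soluble compound, a higher number a more soluble compound), compound 2 gives 73000 nM and compound 3 gives 22000 nM: the measured solubility of compound 2, 73000 nM, and of compound 3, 22000 nM, a 3.3-fold lower number (0.52 log units; beyond the scatter)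

The change removes the ether oxygen and brings in fluorine together, so the compounds shown cannot tell which of the two goes with either shift. Also open, on these data alone, is whether a chlorine in place of the fluorine, or an amine at the end of the chain, would keep the number in the acid ceramidase assay while restoring solubility.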